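Furan-2-yl carbonyl in place of acetyl on compound 3

A few compounds are considered here, and "the series" means these few. Any claim that something is new, unique, unknown or untested is made for them only; others in the source may bear on it.

Compound 3 `CC(=O)Nc1nc(C)nc2cn(-c3ccccc3)nc12` gives 300 nM in an assay on CHO cells for displacement of a labelled ligand from adenosine receptor A3 (Homo sapiens), read by scintillation counting, with a stated time of 60 min (on this read-out higher numbers stand for weaker inhibition and lower numbers for stronger inhibition), the highest of the three numbers recorded. Compound 1 `Cc1nc(NC(=O)c2ccccc2)c2nn(-c3ccccc3)cc2n1` gives 5.6 nM and compound 2 `O=C(Nc1nc(-c2ccccc2)nc2cn(-c3ccccc3)nc12)c1ccco1` gives 24 nM. The step to compound 4 `Cc1nc(NC(=O)c2ccco2)c2nn(-c3ccccc3)cc2n1` is furan-2-yl in place of methyl on a carbonyl carbon. Among the compounds with values here, the one measured step on this carbonyl carbon is a 54-fold higher number from compound 1 to compound 3 (1.73 log units; beyond the scatter), so returning an aromatic ring there should give a large drop. Compound 2 carries the same furan-2-yl carbonyl on a core that differs elsewhere, and its number lies close to that of compound 1. A step of a 20-fold lower number from compound 3 to compound 4 (1.30 log units; beyond the scatter) is therefore expected. Compound 4 is estimated at 15 nM, with a range from 5 nM to 50 nM.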

Compound 4, inhibition constant: 20 nM
The estimate for compound 4 lay 1.3-fold (0.12 log units) below the measured number, and the stated range covers the measured number.
By their numbers in this assay, from the lowest: compound 1; then compounds 4 and 2 (each within the scatter of the next); then compound 3.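

In this assay, furan-2-yl on the carbonyl carbon recovers most of what methyl loses (a 15-fold lower number from compound 3 to compound 4 (1.18 log units; beyond the scatter)), so the gain is not confined to phenyl. The two rings still differ at this position (a 3.6-fold higher number from compound 1 to compound 4 (0.55 log units; beyond the scatter)), with phenyl giving the lower number. With the furan-2-yl carbonyl in place, methyl and phenyl on the aromatic carbon cannot be told apart (a 1.2-fold lower number from compound 2 to compound 4 (0.08 log units; within the scatter)).

On these data alone, whether a non-aromatic ring such as cyclohexyl, or a chain ending in an amine, on this carbonyl carbon would keep the gain remains open. Nothing available gives a reason for these steps.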